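Shortening the aryl chain from propyl to methyl

This account rests on a few compounds, and the source may have more. Where it says the series, first, only, none or still open, it means among the compounds named here.

The compounds share one core, here carried by compound 1 `O=c1nc2oc(CCc3ccccc3)cc2cn1[C@H]1C[C@H](O)[C@@H](CO)O1`, compound 2 `CCCCCc1ccc(C#Cc2cc3cn([C@H]4C[C@H](O)[C@@H](CO)O4)c(=O)nc3o2)cc1`, compound 3 `CCCc1ccc(C#Cc2cc3cn([C@H]4C[C@H](O)[C@@H](CO)O4)c(=O)nc3o2)cc1` and the not yet measured compound 4 `Cc1ccc(C#Cc2cc3cn([C@H]4C[C@H](O)[C@@H](CO)O4)c(=O)nc3o2)cc1`. In an ADME assay on HEL cells (Homo sapiens) for cytotoxicity, with a stated time of 3 days (on this read-out lower numbers stand for higher toxicity in this test and higher numbers for lower toxicity in this test), compound 1 gives > 560000 nM, which is a limit of the assay rather than a number, as stated by the limit of > 560000 nM in this assay, at which 1 of the 3 values shown sits. In this assay, for the measured compounds named here, compound 2 gives 470000 nM and compound 3 gives 87000 nM, so compound 3 stands lowest of the two numbers recorded, with compound 2 as its only numbered neighbour. Going by the values given here, the one measured step that resembles the move ahead is a 5.4-fold lower number from compound 2 to compound 3 (0.73 log units; beyond the scatter), a modest drop when the chain was cut. Compound 4 differs from compound 3 in one place: hydrogen in place of ethyl on a saturated chain carbon bound to an aromatic carbon. Cutting the chain further has no direct precedent among these compounds, and the phenethyl compound 1 offers only a limit, so the expected step is a 1.1-fold higher number from compound 3 to compound 4 (0.06 log units; within the scatter), not expected to go clearly beyond the scatter. Compound 4 is estimated at 100000 nM, within a range from 30000 nM to 400000 nM.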

Compound 4, minimum cytotoxic concentration: >= 510000 nM
Compound 4 ended at the assay's limit; the forecaster's own chance of this, stated with the estimate: 15%; middle value at least 5.1-fold (0.70 log units) away from the limit.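

In this assay, the change from propyl to methyl gives an at least 5.8-fold higher number from compound 3 to compound 4 (0.76 log units; beyond the scatter), the opposite direction to the earlier cut, a 5.4-fold lower number from compound 2 to compound 3 (0.73 log units; beyond the scatter), so at this position the number does not fall steadily as the chain shortens, and compound 4 goes against any such trend. The value of compound 4 is a limit of the assay: the limit of >= 510000 nM in this assay, at which 1 of the 4 values shown sits. Going from pentyl directly to methyl gives an at least 1.0-fold higher number from compound 2 to compound 4 (0.03 log units; that floor lies within the scatter), so the two chain ends cannot be told apart here, and of the three chains only propyl stands clearly lower.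

On these data alone, the step from compound 1 to compound 4 cannot be read, and how far compound 4 lies past its limit stays open. Also open, as far as these compounds go, is where a butyl chain or an ethyl chain would fall, and whether the lower number is particular to propyl.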